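Ring-nitrogen swap tested on a second chalcone arrangement

This account rests on a few compounds, and the source may have more. Where it says the series, first, only, none or still open, it means among the compounds named here.

Compound 1 `COc1ccc(/C=C/C(=O)c2ccccc2-c2ccc(F)cc2)cc1` gives 61 nM in a functional assay on SW480 cells (Homo sapiens) for antiproliferative activity, read by sulforhodamine B assay, with a stated time of 48 h; on this read-out higher numbers stand for weaker inhibition and lower numbers for stronger inhibition. Compound 2 `COc1ccc(/C=C/C(=O)c2ccccc2-c2ccc(F)nc2)cc1` carries 6-fluoropyridin-3-yl in place of 4-fluorophenyl on an aromatic carbon and gives 330 nM in this assay; the step is a 5.4-fold higher number from compound 1 to compound 2 (0.73 log units; beyond the scatter). Compound 3 `COc1ccc(C(=O)/C=C/c2ccccc2-c2ccc(F)cc2)cc1` has the same atoms as compound 1 joined differently; the difference between the two cores is not broken down here. In this assay compound 3 gives 8400 nM, the highest number of the three and beyond the scatter from both others. Compound 4 `COc1ccc(C(=O)/C=C/c2ccccc2-c2ccc(F)nc2)cc1` is not yet measured and differs from compound 3 by 6-fluoropyridin-3-yl in place of 4-fluorophenyl on an aromatic carbon, the same change made between compound 1 and compound 2. For compound 4 the expected step is a 3.6-fold higher number from compound 3 to compound 4 (0.55 log units; beyond the scatter), kept somewhat smaller than a 5.4-fold higher number from compound 1 to compound 2 (0.73 log units; beyond the scatter) because compound 3 already starts from 8400 nM, near where this read-out tends to flatten. Compound 4 is therefore expected at 30000 nM, within 9000 nM to 100000 nM.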

Compound 4, half-maximal inhibitory concentration: 10000 nM
For compound 4 the middle estimate is 3.0-fold (0.48 log units) above the measured one, within the range that was stated.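

In this assay the change of 4-fluorophenyl to 6-fluoropyridin-3-yl gives a 1.2-fold higher number from compound 3 to compound 4 (0.08 log units; within the scatter) on the core of compound 3, and its size on one core does not predict its size on the other: the same change on two cores in this assay, a 5.4-fold higher number (0.73 log units; beyond the scatter) from compound 1 to compound 2 and a 1.2-fold higher number (0.08 log units; within the scatter) from compound 3 to compound 4, 4.5-fold (0.66 log units) apart, beyond the scatter of two such steps. A step taken from the core of compound 1 therefore cannot be applied unchanged to the core of compound 3. These two pairs do not show why the steps differ, nor what the change would do on any further core.

From the compounds shown here alone, it remains open how either core responds when the fluorine on the ring is replaced by an amine or a carboxylic acid. Also open, going by these compounds, is whether a dimethylamino group in place of the methoxy group would leave the comparison intact.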